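This account rests on a few compounds, and the source may have more. Where it says the series, first, only, none or still open, it means among the compounds named here.

In a functional assay on U-937 cells (Homo sapiens) for antiproliferative activity, with a stated time of 48 h (on this read-out lower numbers stand for an effect already at smaller amounts and higher numbers for an effect only at larger amounts of compound), compound 1 (`O=C(CCCCCCC(=O)Nc1cccc(F)c1)NO`) gives 500 nM and compound 2 (`O=C(CCCCCCC(=O)Nc1ccc(C(F)(F)F)cc1)NO`) gives 450 nM. These two numbers lie within the usual scatter of repeated measurements, so compound 2 stands level with compound 1 and neither can be ranked ahead of the other. Compound 3 (`O=C(CCCCCCC(=O)Nc1ccc(I)cc1)NO`) keeps the shared core of compound 2 and changes one group, with iodo in place of trifluoromethyl on an aromatic carbon. Going by the values given here, no pair of measured compounds differs in one place only, so no direct step is available as a guide. Starting from compound 2 at 450 nM, no change beyond the scatter is expected in this assay. The expected move is small, amounting to a 1.1-fold lower number from compound 2 to compound 3 (0.05 log units; within the scatter). Compound 3 is estimated at 400 nM, with an expected range from 180 nM to 900 nM.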

Compound 3, half-maximal effective concentration: 120 nM
Compound 3: the middle estimate sits 3.3-fold (0.52 log units) above what was measured; the whole stated range lies above it.
By their numbers in this assay, from the lowest: compound 3; then compounds 2 and 1 (each within the scatter of the next).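

In this assay, going by these compounds alone, iodo in place of trifluoromethyl on the aromatic carbon para to a large group brings a 3.8-fold lower number from compound 2 to compound 3 (0.57 log units; beyond the scatter) in the first comparison here that differs in one place only. This shows that the group at this position can shift the result beyond the usual scatter, even though neither group carries a hydrogen-bond donor, a hydrogen-bond acceptor or a net charge. Nothing measured here explains the difference between these two groups.

The compounds shown leave open whether other groups at this position, such as bromo, chloro, an amine or a carboxylic acid, would give lower or higher numbers. They also leave open whether iodo would give a similar step when paired with a longer chain.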